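Methylphenyl position in the pyridin-2-yl member of the series

The source may report more compounds than this note shows. Statements on the series, on what has been measured and on what is new or still open speak of the compounds shown alone.

compound 1 `COc1cc(C(=O)c2cn(-c3ccc(C)cc3)cc2-c2ccsc2)cc(OC)c1OC`: 4 nM
compound 2 `COc1cc(C(=O)c2cn(-c3ccc(C)cc3)cc2-c2nccs2)cc(OC)c1OC`: 14 nM
compound 3 `COc1cc(C(=O)c2cn(-c3cccc(C)c3)cc2-c2ccccn2)cc(OC)c1OC`: 140 nM

All three values come from a functional assay on MCF7 cells (Homo sapiens) for inhibition, with a stated time of 96 h; on this read-out higher numbers stand for weaker inhibition and lower numbers for stronger inhibition. Compound 3 gives the highest number of the three, and its gaps to compound 2 and compound 1 are both beyond the scatter. The unmeasured compound 4 `COc1cc(C(=O)c2cn(-c3ccc(C)cc3)cc2-c2ccccn2)cc(OC)c1OC` keeps the pyridin-2-yl group and differs from compound 3 at one place, with 4-methylphenyl in place of 3-methylphenyl on an aromatic nitrogen.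

Going by the values given here, no measured step makes this change alone. Among the compounds with values here, the only measured step, a 3.5-fold higher number from compound 1 to compound 2 (0.54 log units; beyond the scatter), is a modest one at a different place, among compounds that both carry 4-methylphenyl. It shows that the series responds beyond the scatter to a change at that other place, but it gives no size for moving the methyl group. The closest guide is compound 2 at 14 nM, which carries 4-methylphenyl but not pyridin-2-yl, so it supports only a loose expectation. A clear step toward a lower number is expected in this assay, though it is poorly constrained. The expected step is a 3.1-fold lower number from compound 3 to compound 4 (0.49 log units; beyond the scatter). For compound 4 the estimated value is 45 nM, with an expected range from 12 nM to 160 nM.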

Compound 4, half-maximal inhibitory concentration: 36 nM
Estimate against measurement, compound 4: 1.3-fold (0.10 log units) above; the range from low to high includes it.
By their numbers in this assay, from the lowest: compound 1; then compound 2; then compound 4; then compound 3.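

In this assay, 4-methylphenyl in place of 3-methylphenyl on the aromatic nitrogen gives a 3.9-fold lower number from compound 3 to compound 4 (0.59 log units; beyond the scatter), the first size for this change; both groups have the same counts of atoms, donors and acceptors, and only the methyl placement differs. With 4-methylphenyl held constant, the group on the aromatic carbon can now be compared directly: pyridin-2-yl gives a 2.6-fold higher number from compound 2 to compound 4 (0.41 log units; beyond the scatter) against 1,3-thiazol-2-yl and a 9.0-fold higher number from compound 1 to compound 4 (0.95 log units; beyond the scatter) against thiophen-3-yl, so pyridin-2-yl carries the highest number of these three groups. No available measurement accounts for either the methylphenyl step or the steps among these groups.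

On these data alone, the methylphenyl change has been read only with pyridin-2-yl, so its size with thiophen-3-yl or 1,3-thiazol-2-yl remains open. Also open, as far as these compounds go, is how this assay would respond to an amine or a carboxylic acid in place of the methyl group on the phenyl ring.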